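A few compounds are considered here, and "the series" means these few. Any claim that something is new, unique, unknown or untested is made for them only; others in the source may bear on it.

Working notes on the series.

In a functional assay on PANC-1 cells (Homo sapiens) for antiproliferative activity, read by MTT assay, with a stated time of 72 h (on this read-out higher numbers stand for weaker inhibition and lower numbers for stronger inhibition), compound 1 `CC(=O)Oc1ccccc1C(=O)OCC[Se]C#N` gives 15100 nM. Among the three measured members it holds the second highest number. Compound 3 `C[Se]CC(NC(=O)c1ccccc1OC(C)=O)C(=O)O` gives 27600 nM in this assay, and the two numbers sit within the scatter of each other, so no order between compound 1 and compound 3 is claimed. Compound 2 `CC(=O)Oc1ccccc1C(=O)[Se]CC[Se]C(=O)c1ccccc1OC(C)=O` gives 3400 nM in this assay, a lower number than that of compound 1 and one that lies beyond the scatter.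

Compound 4 `CC(=O)Oc1ccccc1C(=O)NCCSC#N` is not yet measured in this assay. Relative to compound 1 the change is a group of 6 heavy atoms (3 carbon, 2 nitrogen, 1 sulfur; no ring) in place of a group of 6 heavy atoms (3 carbon, 1 nitrogen, 1 oxygen, 1 selenium; no ring), on a carbonyl carbon, leaving the shared core untouched. Within the data shown here, no step between measured compounds matches this change, so the direction rests on no recorded pair. The expectation is a step from compound 1 of about a 1.3-fold higher number from compound 1 to compound 4 (0.12 log units; within the scatter) in this assay, most likely no move beyond the scatter, with the uncertainty leaning toward a higher number. The estimate for compound 4 in this assay is 20000 nM, with a range from 7000 nM to 60000 nM.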

Compound 4, half-maximal inhibitory concentration: 8700 nM
The estimate for compound 4 lay 2.3-fold (0.36 log units) above the measured number, and the stated range covers the measured number.
By their numbers in this assay, from the lowest: compound 2; then compounds 4, 1 and 3 (each within the scatter of the next, the first and the last beyond it).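

The (2-(cyanosulfanyl)ethyl)amino group on a carbonyl carbon gives a 1.7-fold lower number from compound 1 to compound 4 (0.24 log units; within the scatter) in this assay, the first step recorded at this place in the series. For this one pair, a group carrying sulfur and a second nitrogen in place of selenium and oxygen therefore leaves the number within the scatter, so selenium in this group is not needed to keep the number there. No measurement shown bears on the reason for this result.

The compounds shown leave open what the exchange of selenium for sulfur and that of oxygen for nitrogen each contribute, as the step carries both at once and no compound shown has only one of them. They also leave open how the number responds to a longer chain in place of the ethyl chain, or to an amine in place of the nitrile.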